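A few compounds are considered here, and "the series" means these few. Any claim that something is new, unique, unknown or untested is made for them only; others in the source may bear on it.

Of the compounds shown here, three have been measured in an ADME assay on J774.A1 cells (Mus musculus) for cytotoxicity; a higher number here means that more compound is tolerated, a lower number that less compound is tolerated. Compound 1 `COc1ccc(-c2nc(N3CCNCC3)nc3ccccc23)c(OC)c1` gives 3.98 ug/mL in this assay. Compound 2 `c1ccc2c(c1)ccn2-c1nc(N2CCNCC2)nc2ccccc12` gives 3.11 ug/mL in this assay, which places it second highest of the three numbers; its gap to compound 1 lies within the scatter, so the two are not separated. Compound 3 `CN1CCN(c2nc(-c3cn(C)c4ccccc34)c3ccccc3n2)CC1` gives 1.03 ug/mL in this assay, and compound 2 stands beyond the scatter above it, so compound 2 is tolerated better than compound 3 on these numbers. No two of these compounds differ in only one place, so no single step between them can be read off.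

Compound 4 `c1ccc(N2CCN(c3nc(-n4ccc5ccccc54)c4ccccc4n3)CC2)cc1` has not yet been measured in this assay. It differs from compound 2 in one place: phenyl in place of hydrogen on an amine nitrogen in a ring. Going by the values given here, nothing among the measured compounds tells how such a change alone moves this read-out. The step from compound 2 to compound 4 is therefore expected to be small and downward, at about the edge of the scatter, which is what a 1.6-fold lower number from compound 2 to compound 4 (0.19 log units; within the scatter) means. For compound 4 the expected value in this assay is 2 ug/mL, with a range from 0.7 ug/mL to 6 ug/mL.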

Compound 4, half-maximal cytotoxic concentration: 5.67 ug/mL
For compound 4 the middle estimate is 2.8-fold (0.45 log units) below the measured one; low and high end bracket the measured number.
By their numbers in this assay, from the lowest: compound 3; then compounds 2, 1 and 4 (each within the scatter of the next).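

In this assay, going by these compounds alone, compounds 2 and 4 form the first pair that differs in one place, and the step (a 1.8-fold higher number from compound 2 to compound 4 (0.26 log units; within the scatter)) gives the first direct reading of phenyl in place of hydrogen on an amine nitrogen in a ring. It shows that this nitrogen, three ring bonds from the ring atom that bears a large group, can carry a phenyl ring with no change in the read-out that stands clear of the scatter, so compounds 2 and 4 are not separated. No measurement available here bears on why the read-out holds across this change.

As far as these compounds go, whether a benzyl group, an acetyl group or a longer chain on the same nitrogen would also leave the read-out within the scatter remains open, as does the effect of a phenyl ring carrying an amine or a carboxylic acid. This single pair also cannot tell whether phenyl on this nitrogen would give a similar step on the core of compound 1.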